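Replacing the substituent on the shared core of compound 2

The compounds below may be only part of what the source reports. "The series", "measured", "known", "first", "only" and "open" are said of these compounds alone.

The series shares the core seen in compound 1 `COc1ccc(-c2nc(N=C(N)N)sc2-c2ccc(OC)cc2)cc1`, which in a functional assay (aorta) with Rattus norvegicus as the target (a higher number here means that more compound is needed for the effect, a lower number that less compound is needed), gives 2 uM. Compound 2 `COc1ccc(-c2nc(/N=C(\N)NC(C)C)sc2-c2ccc(OC)cc2)cc1` carries isopropyl in place of hydrogen on an amine nitrogen and in this assay gives 9.1 uM; compound 3 `COc1ccc(-c2nc(C(=O)N(C)C)sc2-c2ccc(OC)cc2)cc1` gives 3 uM. Compound 2 stands highest of the three numbers, with compound 3 nearest and compound 1 furthest: a 3.0-fold lower number from compound 2 to compound 3 (0.48 log units; beyond the scatter) and a 4.6-fold higher number from compound 1 to compound 2 (0.66 log units; beyond the scatter).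

Compound 4 `COc1ccc(-c2nc(C3=CCN(C)CC3)sc2-c2ccc(OC)cc2)cc1` is not yet measured in this assay. Relative to compound 2 the change is a group of 7 heavy atoms (6 carbon, 1 nitrogen; one six-membered non-aromatic ring with 1 hetero atom) in place of a group of 7 heavy atoms (4 carbon, 3 nitrogen; no ring), on an aromatic carbon. Within the data shown here, two measured steps bear on it. The step of a 4.6-fold higher number from compound 1 to compound 2 (0.66 log units; beyond the scatter) shows that adding isopropyl on the amine nitrogen raised the number. The step of a 3.0-fold lower number from compound 2 to compound 3 (0.48 log units; beyond the scatter) shows that exchanging the group of 7 heavy atoms (4 carbon, 3 nitrogen) for a group of 5 heavy atoms (3 carbon, 1 nitrogen, 1 oxygen) with no hydrogen-bond donors lowered it. Compound 4 likewise ends up with 0 hydrogen-bond donors at that position, so a lowering of a size comparable to a 3.0-fold lower number from compound 2 to compound 3 (0.48 log units; beyond the scatter) is expected, landing near compound 3 rather than compound 1. Compound 4 is accordingly estimated at 4 uM, in the range 1.5 uM to 12 uM. The expected step is a 2.3-fold lower number from compound 2 to compound 4 (0.36 log units; beyond the scatter).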

Compound 4, concentration for half-maximal effect: 5.9 uM
Estimate against measurement, compound 4: 1.5-fold (0.17 log units) below; the measured number falls inside the stated range.
By their numbers in this assay, from the lowest: compounds 1, 3, 4 and 2 (each within the scatter of the next, the first and the last beyond it).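

In this assay the new group, a six-membered non-aromatic ring with 1 hetero atom, cannot be told apart from the group of compound 2, as a 1.5-fold lower number from compound 2 to compound 4 (0.19 log units; within the scatter) shows, so the change of the 2 hydrogen-bond donors of that group for 0 does not by itself separate the two compounds at this position. The same holds against the no-ring group of compound 3, with a 2.0-fold higher number from compound 3 to compound 4 (0.29 log units; within the scatter) as the printed step, so ring and no-ring groups with 0 hydrogen-bond donors are not distinguished here. Among these compounds, only the group of compound 1 stands apart from the new group, with a 3.0-fold higher number from compound 1 to compound 4 (0.47 log units; beyond the scatter) as the one new step that exceeds the scatter, which shows that a ring at this position does not reach the number of the smallest group.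

No measurement is available that accounts for these differences.

As far as these compounds go, whether a saturated piperidine ring, a simple primary amine or a carboxylic acid on this aromatic carbon would fall with compound 3 and compound 4 or with compound 1 remains open. Also open is whether these relations hold once either 4-methoxyphenyl group is replaced, since every compound shown carries both.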